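Dichloro-hydroxymethyl Anilino Variant of a Thiazolopyrimidine Antagonist

The compounds below may be only part of what the source reports. "The series", "measured", "known", "first", "only" and "open" are said of these compounds alone.

Measured compounds:
- Compound 1, `Cc1cccc(C)c1Nc1nc2c(Nc3ccc(C(F)(F)F)cc3)ncnc2s1`: 6 nM
- Compound 2, `CS(=O)(=O)c1nc(Nc2ccc(C(F)(F)F)c(Cl)c2)c2nc(Nc3c(Cl)cccc3Cl)sc2n1`: 77 nM
- Compound 3, `CC(C)CNc1nc(Nc2ccc(C(F)(F)F)cc2)c2nc(Nc3c(Cl)cccc3Cl)sc2n1`: 1 nM

In a functional assay on HEK293 cells for antagonist activity at transient receptor potential cation channel subfamily V member 1 (Rattus norvegicus), read by calcium flux (on this read-out lower numbers stand for stronger inhibition and higher numbers for weaker inhibition), compound 1 gives 6 nM, the second highest of the three numbers. Compound 3 sits nearest, with 1 nM, a gap beyond the usual scatter; compound 2 sits furthest, with 77 nM, also beyond the scatter. For the measured compounds named here, compound 2 and compound 3 differ from compound 1 in more than one place, so no single structural step between measured compounds is available to read from.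

Compound 4, `OCc1cc(Cl)c(Nc2nc3c(Nc4ccc(C(F)(F)F)cc4)ncnc3s2)c(Cl)c1`, differs from compound 1 in one place: 2,6-dichloro-4-(hydroxymethyl)phenyl in place of 2,6-dimethylphenyl on a nitrogen on an aromatic ring. Going by the values given here, compound 3 also carries a 2,6-dichlorophenyl on the same nitrogen and gives the lowest number of the set, but it carries a further change on the shared core, so its value cannot be assigned to the dichloro exchange alone; the hydroxymethyl group appears in no measured compound at all.

The step from compound 1 to compound 4 is therefore expected to be small, a 1.3-fold higher number from compound 1 to compound 4 (0.12 log units; within the scatter), with no firm direction, and within or close to the scatter. Compound 4 is estimated at 8 nM in this assay, with a range from 2 nM to 30 nM.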

Compound 4, half-maximal inhibitory concentration: 0.5 nM
Estimate against measurement, compound 4: 16-fold (1.20 log units) above, outside the stated range (below it).
By their numbers in this assay, from the lowest: compounds 4 and 3 (each within the scatter of the next); then compound 1; then compound 2.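

In this assay, 2,6-dichloro-4-(hydroxymethyl)phenyl in place of 2,6-dimethylphenyl on a nitrogen on an aromatic ring gives a 12-fold lower number from compound 1 to compound 4 (1.08 log units; beyond the scatter), the first single-place step available in the series. It shows that the group on this nitrogen has a large bearing on the read-out on the core of compound 1, and that 2,6-dimethylphenyl can give way to a group of 10 heavy atoms, with 1 hydrogen-bond donor and 1 hydrogen-bond acceptor, with a gain rather than a loss of inhibition. The exchange alters the two methyl groups and adds the hydroxymethyl in a single step, so the gain cannot be divided between those changes, and nothing at hand explains it.

The compounds shown leave open how much of the step would remain with plain 2,6-dichlorophenyl on this nitrogen and the core otherwise as in compound 1. They also leave open whether the hydroxymethyl could be exchanged for a carboxylic acid, an aminomethyl group or a longer chain such as hydroxyethyl while keeping the number of compound 4.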